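The source may hold more compounds than are shown below. What is called first, only, known or untested is meant among the compounds shown, and "the series" means these compounds.

Of the compounds shown here, three have been measured in a functional assay on TK-10 cells (Homo sapiens) for inhibition, read by sulforhodamine B assay, with a stated time of 48 h; a lower number here means that less compound is tolerated, a higher number that more compound is tolerated. Compound 1, with the structure `COc1cc(-c2cc(/C=C/C(=O)c3ccc(N)cc3)[nH]n2)cc(OC)c1OC`, gives 51600 nM in this assay, which is the highest of the three numbers. Compound 2, `COc1ccc(-c2cc(/C=C/C(=O)c3ccc(N)cc3)[nH]n2)cc1OC`, gives 48700 nM; the step of a 1.1-fold lower number from compound 1 to compound 2 (0.03 log units; within the scatter) is within the scatter, so the two cannot be put in order. Compound 3, `COc1cc(C(=O)/C=C/c2cc(-c3cc(OC)c(OC)c(OC)c3)n[nH]2)cc(OC)c1OC`, in which the carbonyl and the double-bonded chain sit the other way round on the shared core, gives 5340 nM, a number far enough from compound 1 to lie beyond the scatter.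

The compound now considered is compound 4, `COc1cc(-c2cc(/C=C/C(=O)c3ccc(F)c(F)c3)[nH]n2)cc(OC)c1OC`. It differs from compound 1 in one place: 3,4-difluorophenyl in place of 4-aminophenyl on a carbonyl carbon. For the measured compounds named here, none of the measured steps touches this change; the only step at hand swaps a methoxy for hydrogen on an aromatic carbon, and the gap from compound 1 to compound 3 concerns a different rearrangement altogether. With no measured guide, the direction of the step from compound 1 to compound 4 cannot be read from the data, and a modest move either way would be unsurprising. The estimate for compound 4 is therefore 30000 nM, with a range from 8000 nM to 120000 nM, meaning an expected step of a 1.7-fold lower number from compound 1 to compound 4 (0.24 log units; within the scatter).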

Compound 4, concentration lethal to 50% of the cells: > 100000 nM
Compound 4 was reported as a limit; the forecaster's own chance of this, stated with the estimate: 5%; middle value at least 3.3-fold (0.52 log units) away from the limit.
By their numbers in this assay, from the lowest: compound 3; then compounds 2 and 1 (each within the scatter of the next). At a limit, above all of these: compound 4.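

Compound 4 is reported only as a limit in this assay, not as a number: the limit of > 100000 nM in this assay, at which 1 of the 4 values shown sits. The earlier compounds shown here gave no step at this place, since compounds 1 and 2 both carry 4-aminophenyl on the carbonyl carbon; replacing that group with 3,4-difluorophenyl now gives an at least 1.9-fold higher number from compound 1 to compound 4 (0.28 log units; that floor lies within the scatter). The change therefore does not bring the number down, but the floor of the step lies within the scatter, so the data cannot show a real rise, and its true size stays hidden behind the limit.

The data do not separate the two things that change with this swap, the loss of the amine and the arrival of two fluorines, so a compound with a plain phenyl, 4-fluorophenyl or 4-hydroxyphenyl on the carbonyl carbon would be needed to tell them apart. As far as these compounds go, it also stays open whether the hydrogen-for-methoxy step, which lies within the scatter with 4-aminophenyl in place, would look the same with 3,4-difluorophenyl, and a group such as a carboxylic acid at this place remains wholly unexplored here.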